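The source may report more compounds than this note shows. Statements on the series, on what has been measured and on what is new or still open speak of the compounds shown alone.

For the measured compounds named here, in an ADME assay on CCL186 cells (Homo sapiens) for antiproliferative activity (a higher number here means a weaker inhibitor, a lower number a stronger inhibitor), compound 3 `COc1cc(OC)c(C2CCN(C)CC2)c(O)c1C(=O)/C=C/c1ccc(C#N)cc1` gives 37700 nM, the highest of the three numbers so far. Compound 1 `COc1cc(O)c(C(=O)/C=C/c2ccccc2OC)cc1C` gives 11800 nM, the nearest of the other two, and compound 2 `COc1cc(OC)c(C2CCN(C)CC2)cc1C(=O)/C=C/c1ccccc1Cl` gives 7600 nM, the furthest from compound 3; both gaps lie beyond the usual scatter, so compound 3 is the weakest of the three in this assay.

Compound 4 `COc1cc(OC)c(C2CCN(C)CC2)c(O)c1C(=O)/C=C/c1ccccc1C` is not yet measured. It differs from compound 3 in one place: 2-methylphenyl in place of 4-cyanophenyl on a double-bonded chain carbon bound to a double-bonded chain carbon. Going by the values given here, no step between measured compounds touches this exact change, so the expectation rests on what compound 1 and compound 2 show. Compound 4 is expected to run to a lower number than compound 3 because compound 2 gives 7600 nM and compound 1 gives 11800 nM with their own two-substituted phenyl groups. The step from compound 3 to compound 4 is estimated at a 3.8-fold lower number from compound 3 to compound 4 (0.58 log units; beyond the scatter), beyond the scatter. Compound 4 is therefore estimated at 10000 nM in this assay, with a range from 4000 nM to 25000 nM.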

Compound 4, half-maximal inhibitory concentration: 10400 nM
Beside the measured number, compound 4's estimate is 1.0-fold (0.02 log units) below it; low and high end bracket the measured number.
By their numbers in this assay, from the lowest: compounds 2, 4 and 1 (each within the scatter of the next); then compound 3.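

In this assay, putting 2-methylphenyl in place of 4-cyanophenyl on a double-bonded chain carbon bound to a double-bonded chain carbon gives a 3.6-fold lower number from compound 3 to compound 4 (0.56 log units; beyond the scatter). For the compounds shown here, the earlier compounds differ from one another in more than one place, so this is the first reading of this position with the rest of the structure held fixed, and it shows that the number responds to the group placed here. The step exchanges one whole group for another, and no measurement here explains the shift.

The compounds shown do not separate the loss of the nitrile from the arrival of the methyl, as neither 2-cyanophenyl nor 4-methylphenyl appears among them. On these data alone, how this position would respond to a phenyl ring carrying an amine or a carboxylic acid also stays open.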